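A few compounds are considered here, and "the series" means these few. Any claim that something is new, unique, unknown or untested is made for them only; others in the source may bear on it.

Compound 1 `COc1ccc(-c2nc3cccc(-c4cc(OC)c(OC)c(OC)c4)c3o2)cc1` gives in a functional assay on MCF7 cells (Homo sapiens) for antiproliferative activity, read by MTT assay, with a stated time of 48 h (on this read-out lower numbers stand for stronger inhibition and higher numbers for weaker inhibition), only a limit, > 25000 nM. Compound 2 `COc1ccc(-c2nc3cccc(-c4cc(OC)c(OC)c(OC)c4)c3o2)cc1F` likewise gives only a limit in this assay, > 25000 nM. Within the data shown here, the single measured step, a step that the two limits leave unreadable from compound 1 to compound 2, cannot be read because both values sit at the limit of > 25000 nM in this assay, at which 2 of the 2 values shown sit. Compound 3 `COc1cc(-c2cccc3nc(-c4cccc(C)c4)oc23)cc(OC)c1OC` differs from compound 1 by 3-methylphenyl in place of 4-methoxyphenyl on an aromatic carbon. Among the measured compounds shown here, no measured step bears directly on this change, and the one step available leaves nothing to read, so neither direction nor size can be expected beyond a further limit. Compound 3 is estimated to give 30000 nM, between 8000 nM and 100000 nM, which means an expected step that the limit leaves unreadable from compound 1 to compound 3.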

Compound 3, half-maximal inhibitory concentration: > 25000 nM
Compound 3 was reported as a limit (the forecaster's own chance of this, stated with the estimate: 70%); the middle value is on the limit's open side.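

Neither the step from compound 1 to compound 3 nor the step from compound 2 to compound 3 can be read, because all three compounds give only a limit: the limit of > 25000 nM in this assay, at which 3 of the 3 values shown sit.

The compounds shown leave open the direction and size of either change in this assay.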